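Sulfonamide benzoxazole series: cytotoxicity notes on a core isomer pair

The source may report more compounds than this note shows. Statements on the series, on what has been measured and on what is new or still open speak of the compounds shown alone.

Measured compounds:
compound 1 `CCc1ccc(S(=O)(=O)Nc2ccc(-c3nc4ccccc4o3)cc2)cc1` gives 82000 nM
compound 2 `O=S(=O)(Nc1ccc2oc(-c3ccccc3)nc2c1)c1cccs1` gives 97000 nM
compound 3 `O=S(=O)(Nc1ccc(-c2nc3ccccc3o2)cc1)c1ccc(Cl)c(C(F)(F)F)c1` gives 69000 nM

In an ADME assay on HEK293 cells (Homo sapiens) for cytotoxicity, read by resazurin assay, with a stated time of 48 h (a lower number here means that less compound is tolerated, a higher number that more compound is tolerated), the three numbers sit in a narrow band. Compound 2 carries the nominally largest number, but the gaps to compound 1 and to compound 3 are both within the scatter, so no ordering among the three can be read from these data. The set shows only that all three sulfonamides are tolerated by the cells up to a similar, high concentration.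

Compound 4 `CCc1ccc(S(=O)(=O)Nc2ccc3oc(-c4ccccc4)nc3c2)cc1` is not yet measured. Relative to compound 2 it differs in one place:
4-ethylphenyl in place of thiophen-2-yl on a sulfonyl sulfur
Going by the values given here, the 4-ethylphenyl group is the one already present in compound 1, whose value of 82000 nM lies within the scatter of compound 2. On that basis no step beyond the scatter is expected in this assay in either direction; the expected step of a 1.1-fold lower number from compound 2 to compound 4 (0.06 log units; within the scatter) is essentially flat. Compound 4 is estimated at 85000 nM, with a range from 45000 nM to 170000 nM.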

Compound 4, half-maximal cytotoxic concentration: 81000 nM
For compound 4 the middle estimate is 1.0-fold (0.02 log units) above the measured one; the measured number falls inside the stated range.
By their numbers in this assay, from the lowest: compounds 3, 4, 1 and 2 (each within the scatter of the next).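

In this assay, going by these compounds alone, the exchange gives the first matched step, a 1.2-fold lower number from compound 2 to compound 4 (0.08 log units; within the scatter), and it stays within the scatter. At this place on a sulfonyl sulfur whose other neighbour is the sulfonamide nitrogen, a five-membered aromatic ring with a hetero atom gives way to a six-membered aromatic ring of carbon only, with no readable change in tolerated concentration, a finding limited to this one pair. No measured information on the origin of this flat step is available.

Going by these compounds, whether a group of another kind at this place, such as an amine or a carboxylic acid, would give a step beyond the scatter remains open. On these data alone, how other changes to the shared core or its phenyl group would read in this assay also remains open.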